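Removing the chloro on the aryl ring: an open step

This account rests on a few compounds, and the source may have more. Where it says the series, first, only, none or still open, it means among the compounds named here.

Measured so far:
- Compound 1, `Cc1ccc(-c2csc(N/N=C/c3ccc(Cl)cc3Cl)n2)cc1`: in a functional assay, read by spectrophotometry, with a stated time of 15 min, tested at 40 ug/mL (a lower number here means a weaker effect, a higher number a stronger effect of the compound at the concentration tested), compound 1 gives 80.4%
- Compound 2, `COc1ccc(-c2csc(N/N=C/c3ccc(Cl)cc3Cl)n2)cc1`: in this assay compound 2 gives 79.7%
- Compound 3, `Clc1ccc(-c2csc(N/N=C/c3ccc(Cl)cc3Cl)n2)cc1`: in this assay compound 3 gives 76.2%

Compound 3 holds the lowest of the three numbers, but the gaps to it are small: a number 3.5 percentage points lower from compound 2 to compound 3 (within the scatter) and a number 4.2 percentage points lower from compound 1 to compound 3 (within the scatter) both lie within the scatter, and so does a number 0.7 percentage points lower from compound 1 to compound 2 (within the scatter). The three measured compounds share one core and differ only at one aromatic carbon, and no exchange there has yet moved this assay beyond the scatter.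

Compound 4, `Clc1ccc(/C=N/Nc2nc(-c3ccccc3)cs2)c(Cl)c1`, continues at the same place: hydrogen in place of chloro on an aromatic carbon. The three measured steps all bear on it, since each swaps one group at this carbon, and none reached beyond the scatter. A fourth exchange at the same place is therefore expected to behave alike, with a number 0.8 percentage points higher from compound 3 to compound 4 (within the scatter) expected as a step not beyond the scatter. For compound 4 the estimate in this assay is 77%, with a range from 65% to 88%.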

Compound 4, a percentage reported as inhibition, at one concentration (the size of the read-out at that concentration, not a potency): 78.9%
For compound 4 the middle estimate is 1.9 percentage points below the measured one, and the stated range covers the measured number.
By their numbers in this assay, from the lowest: compounds 3, 4, 2 and 1 (each within the scatter of the next).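

Taking the substituent off this carbon altogether does not move the read-out in this assay beyond the scatter, against any of the three groups: (a number 2.7 percentage points higher from compound 3 to compound 4 (within the scatter)), (a number 0.8 percentage points lower from compound 2 to compound 4 (within the scatter)) and (a number 1.5 percentage points lower from compound 1 to compound 4 (within the scatter)). The earlier compounds shown here only exchanged one group for another, whereas the 4-chlorophenyl to phenyl change shows that, among the four compounds, none of chloro, methoxy or methyl is needed at this carbon to hold the read-out at the concentration tested. Nothing on hand explains why this position tolerates these exchanges.

As far as these compounds go, whether an amine, a carboxylic acid or a longer chain at this carbon would give a step beyond the scatter remains open. From the compounds shown here alone, the read-out comes from one concentration, so whether any of the four compounds would give a stronger or weaker effect at another concentration also remains open, as does any change elsewhere on the shared core.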